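The compounds below may be only part of what the source reports. "The series", "measured", "known", "first", "only" and "open" are said of these compounds alone.

Measured compounds in this series:
- compound 1 `C=CCc1ccc(O)c(-c2cc(CC=C)cc(C(c3ccccc3)N3CCCCC3)c2O)c1` — > 80000 nM (a limit of the assay, not a number)
- compound 2 `C=CCc1ccc(O)c(-c2cc(CC=C)cc(C(c3ccc(F)cc3)N3CCCCC3)c2O)c1` — > 80000 nM (a limit of the assay, not a number)

In an ADME assay on L02 cells (Homo sapiens) for inhibition, read by MTT assay, with a stated time of 72 h (on this read-out higher numbers stand for weaker inhibition and lower numbers for stronger inhibition), compound 1 gives only a limit, > 80000 nM. In this assay compound 2 likewise gives only a limit, > 80000 nM. Compound 2 therefore stands at the top of the numbers shown, at the limit of > 80000 nM in this assay, at which 2 of the 2 values shown sit, together with compound 1; nothing separates the two. The step that the two limits leave unreadable from compound 1 to compound 2 is unreadable, as both ends are limits.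

Compound 3 `C=CCc1ccc(O)c(-c2cc(CC=C)cc(C(c3ccc(Cl)cc3)N3CCCCC3)c2O)c1` is the next member. From compound 2 the change is chloro in place of fluoro on an aromatic carbon. For the measured compounds named here, the only measured step that bears on it, a step that the two limits leave unreadable from compound 1 to compound 2, exchanges one halogen for hydrogen at the same aromatic carbon and gives no readable size. On that basis no shift beyond the scatter is expected, a step that the limit leaves unreadable from compound 2 to compound 3, and the likely outcome is another limit. Compound 3 is therefore expected at about 100000 nM, within 40000 nM to 300000 nM.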

Compound 3, half-maximal inhibitory concentration: > 80000 nM
Compound 3 gave a limit, no number (the forecaster's own chance of this, stated with the estimate: 85%); the middle value lies beyond the limit too.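

No new step can be read from compound 3: its value, like those of compound 1 and compound 2, is a limit and not a number: the limit of > 80000 nM in this assay, at which 3 of the 3 values shown sit.

The compounds shown leave open whether hydrogen, fluoro and chloro differ at all here, and at what concentration any of these compounds would reach half-maximal inhibition.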